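The source may report more compounds than this note shows. Statements on the series, on what has been measured and on what is new or still open speak of the compounds shown alone.

Measured compounds:
compound 1 `Cc1ccc(N2C(=O)C=CC2OCC(F)(F)F)cc1` with 15800 nM
compound 2 `O=C1C=CC(OCC(F)(F)F)N1c1ccccc1` with 15300 nM
compound 3 `O=C1C=CC(OCC(F)(F)F)N1c1ccccc1F` with 20600 nM

In a functional assay on MDA-MB-231 cells (Homo sapiens) for inhibition (on this read-out higher numbers stand for weaker inhibition and lower numbers for stronger inhibition), compound 2 gives the lowest of the three numbers, but the gaps to compound 1 and compound 3 are within the scatter, so the three compounds cannot be told apart on these results. Compound 4 `COC(=O)c1ccc(N2C(=O)C=CC2OCC(F)(F)F)cc1` is not yet measured. It differs from compound 2 in one place: methoxycarbonyl in place of hydrogen on an aromatic carbon.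

Two measured steps change the same aromatic ring of the shared core. Replacing methyl with hydrogen gave a 1.0-fold lower number from compound 1 to compound 2 (0.01 log units; within the scatter); adding fluoro to another carbon of that ring gave a 1.3-fold higher number from compound 2 to compound 3 (0.13 log units; within the scatter). Neither step moved this assay beyond the scatter, so this ring tolerates small substituents without a visible effect. Within the data shown here, the methoxycarbonyl group is larger than either of those, and no measured compound carries a group of this kind, so the expectation rests only on that tolerance.

Compound 4 is therefore estimated at 15000 nM in this assay, with a range from 6000 nM to 40000 nM, meaning an expected step of a 1.0-fold lower number from compound 2 to compound 4 (0.01 log units; within the scatter), close to no change.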

Compound 4, half-maximal inhibitory concentration: 12100 nM
The estimate for compound 4 lay 1.2-fold (0.09 log units) above the measured number; low and high end bracket the measured number.
By their numbers in this assay, from the lowest: compounds 4, 2, 1 and 3 (each within the scatter of the next).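

In this assay the carbon para to a large group now carries methoxycarbonyl, with 4 heavy atoms and 2 hydrogen-bond acceptors, and the steps to this compound lie within the scatter (a 1.3-fold lower number from compound 2 to compound 4 (0.10 log units; within the scatter) and a 1.3-fold lower number from compound 1 to compound 4 (0.12 log units; within the scatter)) in both comparisons. Until now this ring had shown only methyl and fluoro, so the tolerance seen there also covers a larger group, one replacing either hydrogen or methyl at this place. Nothing given here explains this result.

From the compounds shown here alone, whether an amine or a carboxylic acid on this same carbon would give a step beyond the scatter remains open. Also open, going by these compounds, is what a longer chain in place of the trifluoroethyl end of the shared core would do, as all four compounds carry that same part.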